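Working notes: compound 4 estimated from compound 1

The source may report more compounds than this note shows. Statements on the series, on what has been measured and on what is new or still open speak of the compounds shown alone.

Compound 1 `O=C(NC1CCN(c2ncnc3[nH]ncc23)CC1)c1ccc(Br)cc1` gives 16400 nM in an assay on isolated protein for inhibition of serine/threonine-protein kinase PAK 1 (Homo sapiens), read by ADP-Glo, with a stated time of 40 min (a lower number here means a stronger inhibitor, a higher number a weaker inhibitor), the highest of the three numbers in hand. Compound 2 `O=C(NC1CCN(c2ncnc3[nH]ncc23)CC1)c1ccc(C(F)(F)F)cc1` gives 5740 nM and compound 3 `O=C(NC1CCN(c2ncnc3[nH]ncc23)CC1)c1cccc(C(F)(F)F)c1` gives 2510 nM. Among the measured compounds shown here, the only single-point step among them, a 2.9-fold lower number from compound 1 to compound 2 (0.46 log units; beyond the scatter), is modest. Compound 4 `Cc1cccc(C)c1NC(=O)NC1CCN(c2ncnc3[nH]ncc23)CC1` differs from compound 1 by (2,6-dimethylphenyl)amino in place of 4-bromophenyl on a carbonyl carbon, a change at the carbonyl carbon whose other neighbour is the amide-type nitrogen. For the measured compounds named here, no measured step covers this change; the one comparison available, compound 1 to compound 2, alters a substituent on an aromatic carbon and not the carbonyl carbon itself. The expectation for compound 4 is therefore a step of uncertain direction, a 2.1-fold lower number from compound 1 to compound 4 (0.31 log units; beyond the scatter), with a wide range. Compound 4 is estimated at 8000 nM, between 2000 nM and 32000 nM.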

Compound 4, half-maximal inhibitory concentration: 2160 nM
For compound 4 the middle estimate is 3.7-fold (0.57 log units) above the measured one, within the range that was stated.
By their numbers in this assay, from the lowest: compounds 4 and 3 (each within the scatter of the next); then compound 2; then compound 1.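

In this assay, (2,6-dimethylphenyl)amino in place of 4-bromophenyl on the carbonyl carbon gives a 7.6-fold lower number from compound 1 to compound 4 (0.88 log units; beyond the scatter) at this position. The earlier step changed only a substituent on an aromatic carbon, whereas this one shows that the group on the carbonyl carbon itself can be exchanged, with a nitrogen and a hydrogen-bond donor entering, and the number still falls. No measurement at hand bears on the reason for this step.

The contributions of the entering nitrogen and the two methyl groups remain unseparated. Phenylamino or (2,6-dichlorophenyl)amino on the same carbonyl carbon remains open.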